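A few compounds are considered here, and "the series" means these few. Any claim that something is new, unique, unknown or untested is made for them only; others in the source may bear on it.

Measured compounds in an ADME assay on MT4 cells (Homo sapiens) for cytotoxicity, read by MTT assay; on this read-out higher numbers stand for lower toxicity in this test and lower numbers for higher toxicity in this test:

Compound 1 `O=C(CSc1nccn1-c1ccc(Cl)cc1)Nc1ccccc1[N+](=O)[O-]`. In this assay compound 1 gives only a limit, > 321000 nM.
Compound 2 `COc1ccc(-n2ccnc2SCC(=O)Nc2ccccc2C)cc1`. In this assay compound 2 likewise gives only a limit, > 353000 nM.
Compound 3 `Cc1ccc(-n2ccnc2SCC(=O)Nc2ccccc2[N+](=O)[O-])cc1`. In this assay compound 3 gives 131000 nM.

Compound 1 thus stands at the upper boundary of what this assay reports, as described by the limit of > 321000 nM in this assay, at which 1 of the 3 values shown sits; compound 2 sits at a similar boundary, (the limit of > 353000 nM in this assay, at which 1 of the 3 values shown sits). Among the compounds with values here, the one measured step, an at least 2.4-fold lower number from compound 1 to compound 3 (0.38 log units; beyond the scatter), shows that a methyl in place of chloro on an aromatic carbon brings the number down from the limit into the measured range.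

The next compound is compound 4 `O=C(CSc1nccn1-c1ccc(Cl)cc1)Nc1ccccc1Br`. It differs from compound 1 by bromo in place of nitro on an aromatic carbon. Within the data shown here, no measured step bears directly on the nitro position; the only comparison in hand concerns the other ring. The step from compound 1 to compound 3 is at least modest, so a change of similar or smaller size in this assay is the working expectation for compound 4, without a firm direction. The estimated step of an at least 1.2-fold lower number from compound 1 to compound 4 (0.10 log units; that floor lies within the scatter) is expected to stay close to the scatter. For compound 4 the expected value in this assay is 250000 nM, within the range 100000 nM to 400000 nM.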

Compound 4, half-maximal cytotoxic concentration: > 300000 nM
Compound 4: only a limit was reported (the forecaster's own chance of this, stated with the estimate: 45%); middle value at least 1.2-fold (0.07 log units) away from the limit.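

In this assay compound 4 gives only a limit, > 300000 nM. Compound 1 likewise gives only a limit, > 321000 nM. The step from compound 1 to compound 4 therefore cannot be read. The compounds shown leave open whether bromo in place of nitro on an aromatic carbon changes the read-out at all, and in which direction.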